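The source may hold more compounds than are shown below. What is called first, only, known or untested is meant among the compounds shown, and "the series" means these compounds.

Cytotoxicity across the series is read in an ADME assay on MT2 cells (Homo sapiens) for cytotoxicity, read by XTT assay, with a stated time of 4 days; on this read-out lower numbers stand for higher toxicity in this test and higher numbers for lower toxicity in this test. Compound 1 `Cc1cc(/C=C2\SC(=S)N(Cc3ccccc3)C2=O)c(C)n1-c1ccc(O)c(C(=O)O)c1` gives 159000 nM. For the measured compounds named here, compound 2 `Cc1cc(/C=C2\SC(=S)N(Cc3ccc(C(F)(F)F)cc3)C2=O)c(C)n1-c1ccc(O)c(C(=O)O)c1` gives 45900 nM, the second highest of the three numbers so far; compound 3 `COC(=O)c1ccc(CN2C(=O)/C(=C/c3cc(C)n(-c4ccc(O)c(C(=O)O)c4)c3C)SC2=S)cc1` gives 36900 nM, and the step between these two is a 1.2-fold lower number from compound 2 to compound 3 (0.09 log units; within the scatter). The two substituted benzyl compounds are thus not separated, while both sit clearly lower than compound 1, with a 3.5-fold lower number from compound 1 to compound 2 (0.54 log units; beyond the scatter) and a 4.3-fold lower number from compound 1 to compound 3 (0.63 log units; beyond the scatter).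

The next step goes from compound 2 to compound 4 `COC(=O)c1cccc(CN2C(=O)/C(=C/c3cc(C)n(-c4ccc(O)c(C(=O)O)c4)c3C)SC2=S)c1`: 3-(methoxycarbonyl)phenyl in place of 4-(trifluoromethyl)phenyl on a saturated chain carbon bound to an amide-type nitrogen in a ring.

The step that bears most directly on it is a 1.2-fold lower number from compound 2 to compound 3 (0.09 log units; within the scatter), where the same exchange of groups, at a different position of the ring, left the number within the scatter. Since compound 3 carries the same methoxycarbonyl group and gives 36900 nM, compound 4 is expected to land near that value, with no step beyond the scatter in this assay. The estimate for compound 4 is 38000 nM, between 15000 nM and 100000 nM, meaning an expected step of a 1.2-fold lower number from compound 2 to compound 4 (0.08 log units; within the scatter).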

Compound 4, half-maximal cytotoxic concentration: 38500 nM
Beside the measured number, compound 4's estimate is 1.0-fold (0.01 log units) below it; low and high end bracket the measured number.
By their numbers in this assay, from the lowest: compounds 3, 4 and 2 (each within the scatter of the next); then compound 1.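

Exchanging 4-(methoxycarbonyl)phenyl for 3-(methoxycarbonyl)phenyl on a saturated chain carbon bound to an amide-type nitrogen in a ring leaves the two compounds unseparated in this assay (a 1.0-fold higher number from compound 3 to compound 4 (0.02 log units; within the scatter)). The exchange of 4-(trifluoromethyl)phenyl for 3-(methoxycarbonyl)phenyl also stays unresolved (a 1.2-fold lower number from compound 2 to compound 4 (0.08 log units; within the scatter)), so a second methoxycarbonyl compound now matches compound 2, and this match no longer rests on compound 3 alone. The gap from the plain benzyl compound also holds for this placement (a 4.1-fold lower number from compound 1 to compound 4 (0.62 log units; beyond the scatter)), and none of compounds 2, 3 and 4 goes against it.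

Nothing at hand bears on the reason for that gap. Going by these compounds, whether a carboxylic acid or an amine in place of methoxycarbonyl on the aromatic carbon would stay near these values remains open.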